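The compounds below may be only part of what the source reports. "The series", "measured", "known", "first", "only" and "open" are said of these compounds alone.

Working notes on the series. Compound 1 `O=C(O)[C@@H]1CCCN1C(=O)/C=C/c1ccncc1-c1ccc2ccccc2c1` stands with no single number in an assay on a protein complex for inhibition of CDK8/Cyclin C (Homo sapiens), with a stated time of 1 h (on this read-out higher numbers stand for weaker inhibition and lower numbers for stronger inhibition), where compound 1 is recorded as "not determined" (no result reported). Among the measured compounds shown here, the one measured point is compound 2 `CCOC(=O)/C=C/c1ccncc1-c1ccc2[nH]ccc2c1`, for which in this assay compound 2 gives 107 nM. Compound 3 `O=C(/C=C/c1ccncc1-c1ccc2ccccc2c1)N1CCOCC1` differs from compound 1 by morpholin-4-yl in place of 2-carboxypyrrolidin-1-yl on a carbonyl carbon. For the measured compounds named here, no step between measured compounds exists, so no direction can be read; the change is expected to move the read-out in this assay by no more than the scatter. Compound 3 is therefore estimated at 150 nM, expected within 40 nM to 600 nM.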

Compound 3, half-maximal inhibitory concentration: 60.3 nM
The estimate for compound 3 lay 2.5-fold (0.40 log units) above the measured number; measured number inside the range.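

Among the compounds shown here, with compound 1 recorded as "not determined" (no result reported) in this assay, no step from it to compound 3 can be read. From the compounds shown here alone, the effect of morpholin-4-yl in place of 2-carboxypyrrolidin-1-yl stays open, and no supporting data bear on the result.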